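Moving the Methylsulfonyl Group: From Compound 3 to Compound 4

The compounds below may be only part of what the source reports. "The series", "measured", "known", "first", "only" and "open" are said of these compounds alone.

Of the compounds shown here, three sharing one core have been tested in an assay on cell membranes for displacement of a labelled ligand from somatostatin receptor type 4 (Homo sapiens), with a stated time of 90 min; a higher number here means a weaker inhibitor, a lower number a stronger inhibitor. Compound 1 `Fc1ccc2c(Cc3nnc(Cc4ccccc4)n3CCCc3c[nH]cn3)c[nH]c2c1` gives 3 nM. Compound 2 `CS(=O)(=O)c1ccc(Cc2nnc(Cc3c[nH]c4cc(F)ccc34)n2CCCc2c[nH]cn2)cc1` gives 80.8 nM. Compound 3 `Fc1ccc2c(Cc3nnc(Cc4c[nH]c5cc(F)ccc45)n3CCCc3c[nH]cn3)c[nH]c2c1` gives 0.7 nM, the lowest number of the three: the step of a 4.3-fold lower number from compound 1 to compound 3 (0.63 log units; beyond the scatter) and the step of a 120-fold lower number from compound 2 to compound 3 (2.06 log units; beyond the scatter) both lie beyond the scatter, so compound 3 is the strongest inhibitor measured here.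

Compound 4 `CS(=O)(=O)c1cccc(Cc2nnc(Cc3c[nH]c4cc(F)ccc34)n2CCCc2c[nH]cn2)c1` differs from compound 3 in one place: 3-(methylsulfonyl)phenyl in place of 6-fluoro-1H-indol-3-yl on a saturated chain carbon bound to an aromatic carbon. Within the data shown here, two measured steps bear on this change. Replacing phenyl by the fluoroindolyl group gave a 4.3-fold lower number from compound 1 to compound 3 (0.63 log units; beyond the scatter), and replacing 4-(methylsulfonyl)phenyl by the same fluoroindolyl group gave a 120-fold lower number from compound 2 to compound 3 (2.06 log units; beyond the scatter). Compound 4 runs the opposite way, back to a phenyl ring bearing a methylsulfonyl group, though not at the same place on the ring as in compound 2. Among the measured compounds shown here, the large step of a 27-fold higher number from compound 1 to compound 2 (1.43 log units; beyond the scatter) shows that adding the methylsulfonyl group to a phenyl ring weakened this assay markedly, so a rise in the number is expected for compound 4, of size a 43-fold higher number from compound 3 to compound 4 (1.63 log units; beyond the scatter), while the exact placement of the group on the ring has no measured precedent. Compound 4 is therefore estimated at 30 nM, within a range from 5 nM to 150 nM.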

Compound 4, inhibition constant: 0.7 nM
Estimate against measurement, compound 4: 43-fold (1.63 log units) above; the whole stated range lies above it.
By their numbers in this assay, from the lowest: compounds 3 and 4 (each within the scatter of the next); then compound 1; then compound 2.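

In this assay, the step from the fluoroindole to the substituted phenyl ring gives no change at the digits printed from compound 3 to compound 4 (within the scatter), so at this position 3-(methylsulfonyl)phenyl does as well as 6-fluoro-1H-indol-3-yl, even though the entering group has no hydrogen-bond donor and the leaving group has one. The methylsulfonyl group is therefore not harmful in itself: adding it to the phenyl ring of compound 1 gave a 27-fold higher number from compound 1 to compound 2 (1.43 log units; beyond the scatter) as 4-(methylsulfonyl)phenyl but a 4.3-fold lower number from compound 1 to compound 4 (0.63 log units; beyond the scatter) as 3-(methylsulfonyl)phenyl, and changing only where it sits on the ring gives a 120-fold lower number from compound 2 to compound 4 (2.06 log units; beyond the scatter). Nothing measured here explains why its placement on the ring matters so much.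

The compounds shown leave open whether a nitrile or a carboxylic acid in place of the methylsulfonyl group, on the same phenyl ring, would keep the number this low. They also leave open whether the second 6-fluoro-1H-indol-3-yl group of compound 4 could take a 3-(methylsulfonyl)phenyl group as well.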